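Formyl Capping of the Amino Group in Compound 1

The source may report more compounds than this note shows. Statements on the series, on what has been measured and on what is new or still open speak of the compounds shown alone.

Measured compounds:
compound 1 `Cc1nc2c(OCc3ccccc3)cccn2c1N` — 99%
compound 2 `Nc1cnc2c(OCc3ccccc3)cccn12` — 32%
compound 3 `Cc1nc2c(OCc3ccc(C(F)(F)F)cc3)cccn2c1N` — 78%

In a functional assay on the whole organism with Rattus norvegicus as the target, at a dose of 40 mg/kg by the intraperitoneal route (on this read-out lower numbers stand for less inhibition and higher numbers for more inhibition at the one dose given (going by the name of the read-out)), compound 1 stands highest of the three: compound 3 is the nearest, a number 21 percentage points lower from compound 1 to compound 3 (beyond the scatter), and compound 2 the furthest, a number 67 percentage points lower from compound 1 to compound 2 (beyond the scatter). Compound 4 `Cc1nc2c(OCc3ccccc3)cccn2c1NC=O` differs from compound 1 by formyl in place of hydrogen on a nitrogen on an aromatic ring. Among the compounds with values here, neither measured step touches this nitrogen, so no step bears directly on the change; both known changes away from compound 1, one large and one modest, lowered inhibition. Since compound 1 already sits near the ceiling, a decrease is the more likely outcome, and compound 4 is expected to show a number 29 percentage points lower from compound 1 to compound 4 (beyond the scatter). Compound 4 is therefore estimated at 70%, in the range 35% to 95%.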

Compound 4, a percentage reported as inhibition, in the whole organism at one dose (the size of the read-out at that dose, not a potency): 49%
For compound 4 the middle estimate is 21 percentage points above the measured one; low and high end bracket the measured number.
By their numbers in this assay, from the lowest: compound 2; then compound 4; then compound 3; then compound 1.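

The first change made on this nitrogen proves costly: in this assay, formyl in place of hydrogen gives a number 50 percentage points lower from compound 1 to compound 4 (beyond the scatter). The amino to formylamino change does not remove the read-out, since compound 4 still gives 49%. No evidence is available on what lies behind this loss. The compounds shown leave open whether the drop is particular to formyl or would also follow from an acetyl or a methyl on this nitrogen.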